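A few compounds are considered here, and "the series" means these few. Any claim that something is new, unique, unknown or untested is made for them only; others in the source may bear on it.

Of the compounds shown here, three on the shared core have been read so far: compound 1 (`Cc1cc(NC(=O)Nc2ccccc2OC(F)(F)F)c2ccccc2n1`), compound 2 (`Cc1cc(NC(=O)Nc2ccccc2N)c2ccccc2n1`) and compound 3 (`Cc1cc(NC(=O)Nc2ccccc2C(C)(C)C)c2ccccc2n1`). In an ADME assay on HEK293 cells (Homo sapiens) for cytotoxicity, with a stated time of 72 h (a higher number here means that more compound is needed for the effect, a lower number that less compound is needed), compound 1 gives > 25000 nM as a limit. Compound 2 gives > 25000 nM as a limit too. Compound 3, the starting point here, gives > 25000 nM as a limit as well, so it has no number of its own. Among the compounds with values here, the series so far stands at the limit of > 25000 nM in this assay, at which 3 of the 3 values shown sit, and no compound goes against that.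

The next compound is compound 4 (`CSc1ccccc1NC(=O)Nc1cc(C)nc2ccccc12`), with methylsulfanyl in place of tert-butyl on an aromatic carbon. The measured steps that bear on this change are a step that the two limits leave unreadable from compound 1 to compound 3 and a step that the two limits leave unreadable from compound 2 to compound 3, together with a step that the two limits leave unreadable from compound 1 to compound 2 as the third. None of the three has a readable size. Resting on compound 3 and its limit of > 25000 nM as the reference, no step beyond the scatter and no direction is expected in this assay for this change. The expected step is a number no higher from compound 3 to compound 4 (the limit leaves the size open) as an estimate only. Compound 4 is estimated at 25000 nM, with an expected range from 12000 nM to 50000 nM and a limit again the likeliest report.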

Compound 4, half-maximal effective concentration: > 25000 nM
Compound 4 gave a limit, no number (the forecaster's own chance of this, stated with the estimate: 85%); the middle value sits exactly at the limit.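

No new step can be read among compound 1, compound 2, compound 3 and compound 4 in this assay, as every pair compared there consists of two limits. The compounds shown leave open whether any group on this aromatic carbon would give a value of its own, and how far apart these four compounds lie, with the series resting on one reading: the limit of > 25000 nM in this assay, at which 4 of the 4 values shown sit.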